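The compounds below may be only part of what the source reports. "The series", "measured", "known", "first", "only" and "open" are said of these compounds alone.

Three compounds sharing one core have been examined in an ADME assay on L02 cells (Homo sapiens) for cytotoxicity, read by MTT assay, with a stated time of 48 h; on this read-out higher numbers stand for weaker inhibition and lower numbers for stronger inhibition. Compound 1 `Cc1ccc2[nH]c(=O)c(-c3nc4cc([N+](=O)[O-])ccc4[nH]3)cc2c1` carries a methyl and a nitro group; in this assay compound 1 returns only a limit, > 100000 nM. Compound 2 `O=c1[nH]c2ccccc2cc1-c1nc2cc([N+](=O)[O-])ccc2[nH]1` lacks the methyl; in this assay compound 2 likewise reaches only a limit, > 100000 nM. The step that the two limits leave unreadable from compound 1 to compound 2 cannot be sized, since both ends are limits. Compound 3 `COc1ccc2[nH]c(=O)c(-c3nc4cc(Cl)ccc4[nH]3)cc2c1` bears a methoxy group and a chloro; in this assay compound 3 again gives only a limit, > 100000 nM. Compound 3 thus stands exactly where every measured compound stands, at the limit of > 100000 nM in this assay, at which 3 of the 3 values shown sit.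

Compound 4 `COc1ccc2[nH]c(=O)c(-c3nc4cc([N+](=O)[O-])ccc4[nH]3)cc2c1` differs from compound 3 in a single place: nitro in place of chloro on an aromatic carbon. Among the compounds with values here, no measured step covers this exchange; the only measured step, from compound 1 to compound 2, concerns a methyl and is itself unreadable. Compounds 1 and 2 do carry the nitro group that enters here, and both sit at the limit. The step that the limit leaves unreadable from compound 3 to compound 4 is therefore expected to be nothing beyond the scatter. Compound 4 is expected to give 150000 nM in this assay, most probably as another limit, within a range from 50000 nM to 500000 nM.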

Compound 4, half-maximal inhibitory concentration: > 100000 nM
Compound 4: no number, only a limit (the forecaster's own chance of this, stated with the estimate: 85%); the middle value is on the limit's open side.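

In this assay, compound 4 also gives only a limit, so none of the steps from compound 1, compound 2 or compound 3 to compound 4 can be read: the limit of > 100000 nM in this assay, at which 4 of the 4 values shown sit. The compounds shown leave open at what concentration any of them would inhibit these cells, and whether exchanging methyl, methoxy, hydrogen, nitro or chloro changes that concentration at all.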